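Methyl in place of bromo: notes towards compound 4

The source may hold more compounds than are shown below. What is called first, only, known or untested is meant among the compounds shown, and "the series" means these compounds.

Measured in a functional assay on A549 cells (Homo sapiens) for antiproliferative activity, read by MTT assay, with a stated time of 48 h (on this read-out lower numbers stand for stronger inhibition and higher numbers for weaker inhibition), so far:
compound 1 `Cc1ccc2[nH]c(-c3cn(-c4ccccc4)nc3-c3ccccc3)nc2c1` with 3610 nM
compound 2 `COc1ccc(-c2nn(-c3ccccc3)cc2-c2nc3cc(Cl)ccc3[nH]2)cc1` with 3130 nM
compound 3 `COc1ccc(-c2nn(-c3ccccc3)cc2-c2nc3cc(Br)ccc3[nH]2)cc1` with 6370 nM

Compound 3 stands within the scatter of compound 1 but clear of compound 2. Compound 4 `COc1ccc(-c2nn(-c3ccccc3)cc2-c2nc3cc(C)ccc3[nH]2)cc1` follows from compound 3 by methyl in place of bromo on an aromatic carbon. Going by the values given here, the one measured step on that carbon is a 2.0-fold higher number from compound 2 to compound 3 (0.31 log units; beyond the scatter), with bromo in place of chloro. Compound 1 carries methyl there, differs elsewhere, and gives 3610 nM as a rough guide. A modest move to a lower number in this assay is therefore expected, with no step beyond the scatter. The estimated step is a 1.6-fold lower number from compound 3 to compound 4 (0.20 log units; within the scatter) and this remains an expectation only. Expected for compound 4 is 4000 nM with 1800 nM to 8500 nM as its range.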

Compound 4, half-maximal inhibitory concentration: 5070 nM
Compound 4: middle estimate off by 1.3-fold (0.10 log units), on the low side; the measured number falls inside the stated range.
By their numbers in this assay, from the lowest: compounds 2, 1, 4 and 3 (each within the scatter of the next, the first and the last beyond it).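

In this assay, methyl on this aromatic carbon cannot be separated from either halogen: the steps are a 1.3-fold lower number from compound 3 to compound 4 (0.10 log units; within the scatter) and a 1.6-fold higher number from compound 2 to compound 4 (0.21 log units; within the scatter). Chloro and bromo are printed as beyond the scatter of each other, yet methyl lies within the scatter of both. Methoxy in place of hydrogen on an aromatic carbon also leaves the number within the scatter, at a 1.4-fold higher number from compound 1 to compound 4 (0.15 log units; within the scatter). No measurement on hand offers an explanation for these results. From the compounds shown here alone, whether an amine or a carboxylic acid on this carbon would give a step beyond the scatter remains open.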